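Compound 2 to compound 4: a larger group on nitrogen

The source may hold more compounds than are shown below. What is called first, only, known or untested is meant among the compounds shown, and "the series" means these compounds.

In a functional assay on MDA-MB-231 cells (Homo sapiens) for antiproliferative activity, with a stated time of 4 days (on this read-out higher numbers stand for weaker inhibition and lower numbers for stronger inhibition), compound 1 `CCCCc1ccc2[nH]c(-c3ccc(OC)cc3)c(C=O)c2c1` gives 6.7 nM and compound 2 `CCCCc1ccc2[nH]c(-c3ccc(OC)cc3)c(/C=N/O)c2c1` gives 40 nM while compound 3 `CCCCc1ccc2[nH]c(-c3ccc(C(F)(F)F)cc3)c(/C=N/NC(=O)c3ccc(Cl)cc3)c2c1` gives 329 nM in the same read-out. Compound 2 is therefore second highest of the three numbers, beyond the scatter from both others.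

Compound 4 `CCCCc1ccc2[nH]c(-c3ccc(OC)cc3)c(/C=N/NC(=O)c3ccc(F)cc3)c2c1` departs from compound 2 by ((4-fluorophenyl)carbonyl)amino in place of hydroxy on a double-bonded nitrogen.

Going by the values given here, the one measured step that bears on this change (a 6.0-fold higher number from compound 1 to compound 2 (0.78 log units; beyond the scatter)) is modest and raises the number. Among the compounds with values here, no measured step isolates the exchange itself. Although it differs from compound 4 in more than one place, compound 3 also carries a large group on the double-bonded nitrogen and offers the nearest comparison at 329 nM in this series. A modest rise is therefore expected in this assay, with the estimated step being a 3.8-fold higher number from compound 2 to compound 4 (0.57 log units; beyond the scatter) for this exchange. For compound 4 the estimated value is 150 nM with 40 nM to 600 nM as the expected range.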

Compound 4, half-maximal inhibitory concentration: 19 nM
Estimate against measurement, compound 4: 7.9-fold (0.90 log units) above; the measured number lies below the stated range.
By their numbers in this assay, from the lowest: compound 1; then compound 4; then compound 2; then compound 3.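

In this assay, the double-bonded nitrogen accepts a much larger group without loss: a 2.1-fold lower number from compound 2 to compound 4 (0.32 log units; beyond the scatter) comes with ((4-fluorophenyl)carbonyl)amino in place of hydroxy, so added size at this place does not by itself raise the number. Compound 3 at 329 nM therefore cannot be read as the price of a large group on this nitrogen, since it differs from compound 4 in more than one place. Nothing measured here accounts for the lower number of compound 4.

From the compounds shown here alone, whether that lower number belongs to the carbonyl or to the aromatic ring stays open; a plain amino or an acetylamino group on the same nitrogen would separate the two. Compound 3 carries trifluoromethyl where compound 4 carries methoxy, and chloro where compound 4 carries fluoro. Going by these compounds alone, no measured step separates these two differences.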